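This account rests on a few compounds, and the source may have more. Where it says the series, first, only, none or still open, it means among the compounds named here.

Measured compounds in the series:
Compound 1 `CC1CCN(C(=O)CCNC(=O)c2ccc(S(C)(=O)=O)c([N+](=O)[O-])c2)CC1`: in an assay on isolated protein for inhibition of thyroid hormone receptor beta (Homo sapiens), read by fluorescence polarization (a lower number here means a stronger inhibitor, a higher number a weaker inhibitor), compound 1 gives > 60000 nM, which is a limit of the assay and not a number.
Compound 2 `CS(=O)(=O)c1ccc(C(=O)NCCCC(=O)N2CCCCC2)cc1[N+](=O)[O-]`: in this assay compound 2 gives > 60000 nM, again a limit.
Compound 3 `CS(=O)(=O)c1ccc(C(=O)NCCC(=O)N2CCCCC2)cc1[N+](=O)[O-]`: in this assay compound 3 gives > 60000 nM, also a limit.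

Compound 2 therefore stands at the limit of > 60000 nM in this assay, at which 3 of the 3 values shown sit, with no number of its own. Compound 4 `CN(Cc1ccccc1F)C(=O)CCCNC(=O)c1ccc(S(C)(=O)=O)c([N+](=O)[O-])c1` has not been measured; the change is (2-fluorobenzyl)(methyl)amino in place of piperidin-1-yl on a carbonyl carbon. The steps that touch the same part of compound 2 are a step that the two limits leave unreadable from compound 1 to compound 2 and a step that the two limits leave unreadable from compound 2 to compound 3, and the third step, a step that the two limits leave unreadable from compound 1 to compound 3, is no more readable. None gives a size or direction, so no step beyond the scatter can be expected, and a further limit is the likeliest outcome. The estimate for compound 4 is 60000 nM (range 20000 nM to 200000 nM). This amounts to an expected step of a number no higher from compound 2 to compound 4 (the limit leaves the size open).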

Compound 4, half-maximal inhibitory concentration: > 60000 nM
Compound 4 was reported as a limit (the forecaster's own chance of this, stated with the estimate: 75%); the middle value lies on the limit itself.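

No step can be read from compound 2 to compound 4: each value is a limit, not a number. The compounds shown leave open whether any group on the carbonyl carbon gives a number rather than a limit.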